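This account rests on a few compounds, and the source may have more. Where it says the series, first, only, none or still open, it means among the compounds named here.

Compound 2 `Cc1cccc(-c2nn(-c3ccc(F)cc3F)cc2CNCCN2CCN(C)CC2)c1` belongs to a set of three measured compounds examined in an ADME assay on Huh-7 cells (Homo sapiens) for cytotoxicity; on this read-out higher numbers stand for lower toxicity in this test and lower numbers for higher toxicity in this test. In this assay compound 1 `CN1CCN(CCCNCc2cn(-c3ccc([N+](=O)[O-])cc3)nc2-c2ccc(Cl)cc2)CC1` gives 3700 nM. For compound 2 this assay reports only a limit, > 20000 nM. For compound 3 `Cc1ccccc1-c1nn(-c2cc(F)ccc2F)cc1CNCCN1CCN(C)CC1` this assay likewise reports a limit, > 20000 nM. Going by the values given here, compound 2 thus sits at the limit of > 20000 nM in this assay, at which 2 of the 3 values shown sit, and no step between measured compounds in this assay can be given. Compound 4 `COC(=O)c1ccc(-c2nn(-c3ccc(F)cc3F)cc2CNCCN2CCN(C)CC2)cc1` differs from compound 2 by 4-(methoxycarbonyl)phenyl in place of 3-methylphenyl on an aromatic carbon, in words 4-(methoxycarbonyl)phenyl in place of 3-methylphenyl on an aromatic carbon. Among the compounds with values here, with no measured step to rest on, the step from compound 2 to compound 4 is expected to be none beyond the scatter a number no higher from compound 2 to compound 4 (the limit leaves the size open). Compound 4 is therefore estimated at 20000 nM, between 8000 nM and 50000 nM in this assay.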

Compound 4, half-maximal cytotoxic concentration: > 20000 nM
Compound 4 gave a limit, no number (the forecaster's own chance of this, stated with the estimate: 60%); the middle value lies on the limit itself.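

In this assay compound 4 gives only a limit, > 20000 nM. Going by these compounds alone, compound 2 also stands at a limit, so no step between compound 2 and compound 4 can be read. As far as these compounds go, whether 4-(methoxycarbonyl)phenyl in place of 3-methylphenyl shifts the read-out at all stays open.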